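A few compounds are considered here, and "the series" means these few. Any claim that something is new, unique, unknown or untested is made for them only; others in the source may bear on it.

Measured in an ADME assay on the whole organism for metabolic stability, with Rattus norvegicus as the target; on this read-out higher numbers stand for a longer-lived compound and lower numbers for a shorter-lived compound
- Compound 1 `CCS(=O)(=O)n1cc2c(n1)CN([C@H]1CO[C@H](c3cc(F)ccc3F)[C@@H](N)C1)C2` gives 5.2 h
- Compound 2 `CCC(=O)Nc1n[nH]c2c1CN([C@H]1CO[C@H](c3cc(F)ccc3F)[C@@H](N)C1)C2` gives 2.2 h
- Compound 3 `N[C@H]1C[C@@H](N2Cc3[nH]nc(NC(=O)C4CC4)c3C2)CO[C@@H]1c1cc(F)ccc1F` has not yet been measured

Compound 2 holds the lower of the two numbers at 2.2 h and compound 1 stands higher at 5.2 h by more than the usual scatter. Among the measured compounds shown here, no pair of measured compounds differs in one place only, so the series offers no direct precedent for a single change.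

Compound 3 differs from compound 2 in one place: cyclopropyl in place of ethyl on a carbonyl carbon and in words this is cyclopropyl in place of ethyl on a carbonyl carbon. For the measured compounds named here, compound 2 is the only measured compound that carries the propanoylamino group, and neither measured compound carries the (cyclopropylcarbonyl)amino group. The starting point for the expectation is therefore compound 2 at 2.2 h with the range kept wide. No step beyond the scatter is expected in this assay and the estimated move is small and slightly upward, a 1.1-fold higher number from compound 2 to compound 3 (0.06 log units; within the scatter) as the expected step. Compound 3 is expected at 2.5 h with an estimated range from 1.3 h to 4.8 h of half-life.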

Compound 3, half-life: 5.5 h
Compound 3: middle estimate off by 2.2-fold (0.34 log units), on the low side; the whole stated range lies below it.
By their numbers in this assay, from the lowest: compound 2; then compounds 1 and 3 (each within the scatter of the next).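

In this assay, among the compounds shown here, the exchange of ethyl for cyclopropyl on a carbonyl carbon gives a 2.5-fold higher number from compound 2 to compound 3 (0.40 log units; beyond the scatter) and is the first single-place step, which shows that half-life in this assay responds to the group at this place. The step goes with one more heavy atom and a three-membered ring of carbon only, while the counts of hydrogen-bond donors and acceptors and the net charge stay the same on both sides of the change. No measured information bears on the origin of this step, so it stands as an observation without an assigned cause.

A single step cannot separate the ring from the added carbon, so open-chain isopropyl and the larger cyclobutyl on the same carbonyl carbon remain the obvious comparisons for telling those two apart. The compounds shown also leave open whether this step would carry over to another core or to a longer chain such as butanoyl in place of propanoyl.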